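Swapping Morpholine for Isopropylpiperazine in a Serine Protease Inhibitor

The source may hold more compounds than are shown below. What is called first, only, known or untested is meant among the compounds shown, and "the series" means these compounds.

Measured so far:
compound 1 `CC(C)[C@@H](NS(=O)(=O)Cc1ccccc1)C(=O)N1CCC[C@H]1C(=O)NCc1ccc(C(=N)N)cc1` gives 76 nM
compound 2 `N=C(N)c1ccc(CNC(=O)[C@@H]2CCCN2C(=O)[C@@H](CC(=O)N2CCOCC2)NS(=O)(=O)Cc2ccccc2)cc1` gives 183 nM

Compound 2 holds the higher of the two numbers in an assay on isolated protein for inhibition of transmembrane protease serine 11D (Homo sapiens), read by fluorescence; a higher number here means a weaker inhibitor, a lower number a stronger inhibitor; compound 1 sits a clear way below it, the step being a 2.4-fold higher number from compound 1 to compound 2 (0.38 log units; beyond the scatter). Compound 3 `CC(C)N1CCN(C(=O)C[C@@H](NS(=O)(=O)Cc2ccccc2)C(=O)N2CCC[C@H]2C(=O)NCc2ccc(C(=N)N)cc2)CC1` differs from compound 2 only in the amide at the end of the side chain: 4-isopropylpiperazin-1-yl in place of morpholin-4-yl on a carbonyl carbon. Within the data shown here, no measured step bears directly on this exchange; the single step recorded, a 2.4-fold higher number from compound 1 to compound 2 (0.38 log units; beyond the scatter), concerns a different part of the side chain and was only modest. With no guidance beyond that, the change is expected to produce at most a small shift in this assay, and the direction cannot be read from the two values shown. The estimate for compound 3 is 150 nM, with a range from 55 nM to 450 nM, which corresponds to an expected step of a 1.2-fold lower number from compound 2 to compound 3 (0.09 log units; within the scatter).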

Compound 3, inhibition constant: 221 nM
The estimate for compound 3 lay 1.5-fold (0.17 log units) below the measured number, within the range that was stated.
By their numbers in this assay, from the lowest: compound 1; then compounds 2 and 3 (each within the scatter of the next).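

In this assay, 4-isopropylpiperazin-1-yl in place of morpholin-4-yl on the carbonyl carbon gives a 1.2-fold higher number from compound 2 to compound 3 (0.08 log units; within the scatter) and so leaves the number unchanged within the scatter, which means these two amides cannot be told apart at the end of this side chain. Measured against the isopropyl of compound 1, the new side chain gives a 2.9-fold higher number from compound 1 to compound 3 (0.46 log units; beyond the scatter) and thus joins the morpholine amide in remaining clearly apart from compound 1, so the exchange of amide does not close that gap. Nothing measured here accounts for either step.

The compounds shown leave open whether a side chain ending in a carboxylic acid or a primary amide would come closer to compound 1 at 76 nM in this assay than either of these amides does. They also leave open what a longer chain carrying the same amides would do, or a piperazine with an acetyl group in place of the isopropyl.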